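The compounds below may be only part of what the source reports. "The series", "measured", "known", "first", "only" and "open" are said of these compounds alone.

Measured compounds:
Compound 1 `COc1cc([C@@H]2Oc3c(OC)cc(CCCO)cc3[C@H]2CO[C@@H]2O[C@@H](C)[C@H](O)[C@@H](O)[C@H]2O)cc(OC)c1O` — in a functional assay on HCT-15 cells (Homo sapiens) for cytotoxicity, read by sulforhodamine B assay (on this read-out higher numbers stand for weaker inhibition and lower numbers for stronger inhibition), compound 1 gives > 10000 nM, a limit of the assay.
Compound 2 `COc1cc([C@H]2Oc3c(OC)cc(CCCO)cc3[C@@H]2CO[C@@H]2O[C@@H](C)[C@H](O)[C@@H](O)[C@H]2O)cc(OC)c1O` — in this assay compound 2 gives > 10000 nM, a limit of the assay.
Compound 3 `COc1cc([C@H]2Oc3c(OC)cc(CCCO)cc3[C@@H]2CO[C@@H]2O[C@H](CO)[C@@H](O)[C@H](O)[C@H]2O)ccc1O` — in this assay compound 3 gives > 10000 nM, a limit of the assay.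

For the measured compounds named here, compound 3 stands at the limit, where every value so far sits (the limit of > 10000 nM in this assay, at which 3 of the 3 values shown sit); no number separates it from the other two. Going by the values given here, the one comparable pair, compounds 1 and 2, differ only in configuration as drawn (the fact that compounds 1 and 2 differ only in the configuration as drawn), and their step that the two limits leave unreadable from compound 1 to compound 2 cannot be read between two limits. Compound 4 `COc1cc([C@H]2Oc3c(OC)cc(CCCO)cc3[C@@H]2CO[C@@H]2O[C@@H](C)[C@H](O)[C@@H](O)[C@H]2O)ccc1O` is the next member. Relative to compound 3 the change is 3,4,5-trihydroxy-6-methyloxan-2-yl in place of 3,4,5-trihydroxy-6-(hydroxymethyl)oxan-2-yl on an oxygen on a saturated carbon. Among the compounds with values here, no measured step bears on this exchange of sugar, and the only step present is itself unreadable, so there is no basis for expecting movement in this assay beyond the scatter. The expectation is therefore that compound 4 again returns a limit, with an estimated step that the limit leaves unreadable from compound 3 to compound 4. The estimate for compound 4 is 20000 nM, in the range 8000 nM to 60000 nM.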

Compound 4, half-maximal inhibitory concentration: > 10000 nM
Compound 4: a limit, no number (the forecaster's own chance of this, stated with the estimate: 85%); the middle value lies beyond the limit too.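

For the compounds shown here, no step to compound 4 can be read, neither from compound 3 nor from compound 2, because these compounds all sit at one limit: the limit of > 10000 nM in this assay, at which 4 of the 4 values shown sit. Going by these compounds, with no number, it remains open whether the sugar, the methoxy group or the configuration as drawn affects cytotoxicity.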